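The source may report more compounds than this note shows. Statements on the series, on what has been measured and on what is new or still open speak of the compounds shown alone.

Compound 1 `CN1CCC[C@H]1COc1cncc(-c2ccccc2)c1` gives 0.11 nM in an assay on membranes from brain for binding affinity to Neuronal acetylcholine receptor; alpha4/beta2 (Rattus norvegicus); a higher number here means a weaker inhibitor, a lower number a stronger inhibitor. Compound 2 `Cc1ccccc1-c1cncc(OC[C@@H]2CCCN2C)c1`, which carries a methyl in place of hydrogen on an aromatic carbon, gives 1.1 nM in this assay, so that a 10-fold higher number from compound 1 to compound 2 (1.00 log units; beyond the scatter). Compound 3 `CN1CCC[C@H]1COc1cncc(-c2cccc([N+](=O)[O-])c2)c1` gives 0.465 nM in this assay, and a 4.2-fold higher number from compound 1 to compound 3 (0.63 log units; beyond the scatter); compound 3 thus stands second highest of the three numbers, between the other two. Compound 4 `CN1CCC[C@H]1COc1cncc(-c2cccc(N)c2)c1` differs from compound 3 by amino in place of nitro on an aromatic carbon. Among the measured compounds shown here, no measured step swaps one substituent for another; the two known steps show only that placing a group on that ring weakens binding moderately. An amino there is therefore expected to leave compound 4 near compound 3, with a 1.1-fold higher number from compound 3 to compound 4 (0.03 log units; within the scatter) as the expected step. Compound 4 is estimated at 0.5 nM in this assay, ranging from 0.15 nM to 2 nM.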

Compound 4, inhibition constant: 0.43 nM
Estimate against measurement, compound 4: 1.2-fold (0.07 log units) above; low and high end bracket the measured number.
By their numbers in this assay, from the lowest: compound 1; then compounds 4 and 3 (each within the scatter of the next); then compound 2.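

In this assay, nitro, with 3 heavy atoms and no hydrogen-bond donor, and amino, with 1 heavy atom and 1 hydrogen-bond donor, are not told apart at this aromatic carbon, with a 1.1-fold lower number from compound 3 to compound 4 (0.03 log units; within the scatter). Amino still costs binding against plain hydrogen, with a 3.9-fold higher number from compound 1 to compound 4 (0.59 log units; beyond the scatter), while 3-aminophenyl in place of 2-methylphenyl gives a 2.6-fold lower number from compound 2 to compound 4 (0.41 log units; beyond the scatter). No available evidence accounts for these results. The compounds shown leave open whether a carboxylic acid, a methoxy or a longer chain at this carbon would fit the same picture.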